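The source may report more compounds than this note shows. Statements on the series, on what has been measured and on what is new or still open speak of the compounds shown alone.

Three compounds with a shared core have been examined in a functional assay on CHO-K1 cells for antagonist activity at prostaglandin D2 receptor 2 (Homo sapiens), read by scintillation counting and GTPgammaS binding, with stated times of 1 h and 2 h; a higher number here means a weaker inhibitor, a lower number a stronger inhibitor. Compound 1 `Cc1c(CC(=O)O)c(-c2ccccc2)nn1Cc1ccc(S(C)(=O)=O)cc1` gives "not active" (no number reported). Compound 2 `Cc1c(CC(=O)O)c(-c2ccc(O)nc2)nn1C(c1ccc(F)cc1)c1ccc(F)cc1` likewise gives "not active" (no number reported). Compound 3 `Cc1c(CC(=O)O)c(-c2ccccc2)nn1C(c1ccc(F)cc1)c1ccc(F)cc1` is the only one of the three to yield a number, giving 1100 nM in this assay, so it stands alone as the sole quantified point and the reference for what follows.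

Compound 4 `Cc1c(CC(=O)O)c(-c2ccccc2)nn1C(c1ccc(F)cc1)c1ccc(S(C)(=O)=O)cc1` differs from compound 3 in one place: methylsulfonyl in place of fluoro on an aromatic carbon. Going by the values given here, there is no measured pair that shows what this particular exchange does on this core, so the expectation rests on the structural change alone. A modest gain in potency is expected for compound 4, with the step from compound 3 to compound 4 estimated at a 2.2-fold lower number from compound 3 to compound 4 (0.34 log units; beyond the scatter), though a change within the usual scatter cannot be ruled out. The half-maximal inhibitory concentration of compound 4 in this assay is expected at about 500 nM, with a plausible range from 80 nM to 3000 nM.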

Compound 4, half-maximal inhibitory concentration: 5000 nM
For compound 4 the middle estimate is 10-fold (1.00 log units) below the measured one, outside the stated range (above it).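

In this assay, replacing fluoro with methylsulfonyl on this aromatic carbon gives a 4.5-fold higher number from compound 3 to compound 4 (0.66 log units; beyond the scatter), so the exchange weakens inhibition but still leaves a measurable value. Going by these compounds alone, this is the first measured step on the shared core, and it shows that the compound is sensitive to the group at this place, with fluoro giving the stronger inhibitor of the two. Nothing available here explains why the number rises with this exchange.

From the compounds shown here alone, two groups at one place cannot show whether the outcome follows from the methylsulfonyl group alone, so the effect of a nitrile, a methoxy group or a chlorine there remains open. Going by these compounds, it also remains open whether an amine or a carboxylic acid at this place would keep a measurable value.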